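Ring Expansion on the Amide Chain and Tolerated Concentration

This account rests on a few compounds, and the source may have more. Where it says the series, first, only, none or still open, it means among the compounds named here.

Compound 1, `O=C(CCl)Nc1ccc(-c2nc3cc(C(F)(F)F)ccc3[nH]2)cc1`, 35000 nM in an ADME assay on Vero cells (Chlorocebus sabaeus) for cytotoxicity; a higher number here means that more compound is tolerated, a lower number that less compound is tolerated
Compound 2, `O=C(CN1CCCC1)Nc1ccc(-c2nc3cc(C(F)(F)F)ccc3[nH]2)cc1`, > 100000 nM in this assay

In this assay compound 1 gives 35000 nM. For compound 2 this assay reports only a limit, > 100000 nM, so compound 2 stands at a limit rather than at a number. Among the compounds with values here, the one measured step, an at least 2.8-fold higher number from compound 1 to compound 2 (0.45 log units; beyond the scatter), rests on (the limit of > 100000 nM in this assay, at which 1 of the 2 values shown sits). Compound 3, `O=C(CN1CCCCC1)Nc1ccc(-c2nc3cc(C(F)(F)F)ccc3[nH]2)cc1`, differs from compound 2 by piperidin-1-yl in place of pyrrolidin-1-yl on a saturated chain carbon bound to a carbonyl carbon. Within the data shown here, no measured step covers this change; the account therefore expects no step beyond the scatter, a number no higher from compound 2 to compound 3 (the limit leaves the size open), and compound 3 is estimated at 100000 nM, within 50000 nM to 200000 nM.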

Compound 3, half-maximal cytotoxic concentration: 31000 nM
The estimate for compound 3 lay 3.2-fold (0.51 log units) above the measured number, and the stated range ends above it.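

In this assay piperidin-1-yl in place of pyrrolidin-1-yl on a saturated chain carbon bound to a carbonyl carbon gives an at least 3.2-fold lower number from compound 2 to compound 3 (0.50 log units; beyond the scatter) and so one ring size differs from the other at this position. Piperidin-1-yl in place of chloro gives a 1.1-fold lower number from compound 1 to compound 3 (0.05 log units; within the scatter) and so a ring amine here does not by itself go with a higher number. Compound 2 stands at a limit, so the size of its step to compound 3 stays open: the limit of > 100000 nM in this assay, at which 1 of the 3 values shown sits.

On these data alone, whether morpholine, azepane or an open-chain diethylamine on that carbon would follow pyrrolidin-1-yl or piperidin-1-yl remains open.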